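Extending the acetoxy side chain of compound 2

The source may report more compounds than this note shows. Statements on the series, on what has been measured and on what is new or still open speak of the compounds shown alone.

In a functional assay on A549 cells (Homo sapiens) for inhibition, read by XTT assay, with a stated time of 48 h (on this read-out higher numbers stand for weaker inhibition and lower numbers for stronger inhibition), compound 1 (`COc1ccc(C(=O)/C(=C/c2ccccc2F)COC(C)=O)cc1`) gives 22500 nM, and compound 2 (`COc1ccc(C(=O)/C(=C/C2CCCCC2)COC(C)=O)cc1`) gives 90000 nM, the higher of the two numbers. Compound 3 (`COc1ccc(C(=O)/C(=C/C2CCCCC2)CC(C)OC(C)=O)cc1`) has 1-acetoxyethyl in place of acetoxy on a saturated chain carbon bound to a double-bonded chain carbon. Going by the values given here, the only measured step, a 4.0-fold higher number from compound 1 to compound 2 (0.60 log units; beyond the scatter), is modest and lies at another place, so it bears only indirectly. Among the compounds with values here, no measured step covers this change, and no shift beyond the scatter is expected in this assay. The expected step is a 1.2-fold lower number from compound 2 to compound 3 (0.08 log units; within the scatter). The estimate for compound 3 is 75000 nM, with an expected range of 30000 nM to 170000 nM.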

Compound 3, half-maximal inhibitory concentration: 98000 nM
Estimate against measurement, compound 3: 1.3-fold (0.12 log units) below; the measured number falls inside the stated range.
By their numbers in this assay, from the lowest: compound 1; then compounds 2 and 3 (each within the scatter of the next).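

In this assay, going by these compounds alone, 1-acetoxyethyl in place of acetoxy on a saturated chain carbon bound to a double-bonded chain carbon gives a 1.1-fold higher number from compound 2 to compound 3 (0.04 log units; within the scatter), the first reading at this place. With cyclohexyl held constant, the larger group leaves compound 3 level with compound 2 within the scatter, so this change neither gains nor loses inhibition here. No supporting data bear on this result.

Still open, going by these compounds, is whether the same change stays silent with 2-fluorophenyl in place of cyclohexyl. Also open, on these data alone, is whether an amine, a carboxylic acid or a longer chain at this place would move the number beyond the scatter.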